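Working notes: from compound 3 to compound 4

The source may hold more compounds than are shown below. What is called first, only, known or untested is meant among the compounds shown, and "the series" means these compounds.

Values in an ADME assay on HCT-116 cells (Homo sapiens) for cytotoxicity, read by CellTiter-Glo, with a stated time of 72 h (on this read-out lower numbers stand for stronger inhibition and higher numbers for weaker inhibition), each a limit and not a number
compound 1 `CC1CCN(C2CCN(S(=O)(=O)c3cccc(C(F)(F)F)c3)CC2)CC1` limit > 5000 nM
compound 2 `CC1CCN(C2CCN(S(=O)(=O)c3ccc(C#N)cc3)CC2)CC1` limit > 5000 nM
compound 3 `CC1CCN(C2CCN(S(=O)(=O)c3cccnc3)CC2)CC1` limit > 10000 nM

Compound 3 stands at the limit of > 10000 nM in this assay, at which 1 of the 3 values shown sits, so it has a limit and no number. Compound 1 and compound 2 stand at the limit of > 5000 nM in this assay, at which 2 of the 3 values shown sit, again without a number.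

Compound 4 `CC1CCN(C2CCN(S(=O)(=O)c3cccc(N)c3)CC2)CC1` is still to be measured in this assay. Its change is 3-aminophenyl in place of pyridin-3-yl on a sulfonyl sulfur.

Among the compounds with values here, the one measured step at this place is a step that the two limits leave unreadable from compound 2 to compound 3, and it offers no size to carry over. The expectation therefore rests on the limits alone, and another limit is the likeliest report. The expected step is a number no higher from compound 3 to compound 4 (the limit leaves the size open), with no size or direction expected beyond the scatter. For compound 4 the estimate is 10000 nM, with an expected range from 5000 nM to 20000 nM in this assay.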

Compound 4, half-maximal inhibitory concentration: > 5000 nM
Compound 4: no number, only a limit; the forecaster's own chance of this, stated with the estimate: 85%; the middle value does not contradict the limit.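

In this assay compound 4 gives > 5000 nM, a limit and not a number. The steps to compound 4 from compound 1, compound 2 and compound 3 cannot be read: all four values are limits. The compounds shown leave open whether the group on the sulfonyl sulfur changes the read-out at all.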